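A few compounds are considered here, and "the series" means these few. Any claim that something is new, unique, unknown or untested is made for them only; others in the source may bear on it.

Measured so far in a functional assay on HT-29 cells (Homo sapiens) for cytotoxicity, read by XTT assay, with a stated time of 72 h; on this read-out higher numbers stand for weaker inhibition and lower numbers for stronger inhibition:

Compound 1 `CN/N=C(/c1cc(OC)c(OC)c(OC)c1)c1ccc2c(ccn2C)c1` gives > 1000 nM in this assay, a limit rather than a number.
Compound 2 `COc1cc(/C(=N/C(=O)OC(C)(C)C)c2ccc3c(ccn3C)c2)cc(OC)c1OC` gives > 1000 nM in this assay, again a limit and not a number.

Among the compounds with values here, the single step between them, a step that the two limits leave unreadable from compound 1 to compound 2, cannot be sized because the limit of > 1000 nM in this assay, at which 2 of the 2 values shown sit, is where both values sit. Compound 2 therefore stands only at a limit, with no numerical position within the series.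

Compound 3 `COc1cc(/C(=N\C(=O)OC(C)(C)C)c2ccc3c(ccn3C)c2)cc(OC)c1OC` is the geometric partner of compound 2: the two compounds have the same atoms and bonds and differ only in configuration as drawn: 1 of 1 stereo elements differ; a double bond is drawn E in compound 2 and Z in compound 3. Within the data shown here, no measured step bears on a change of double-bond geometry, and the one measured step is itself unreadable, so no direction can be drawn from the data. The only anchor is that both values shown sit at the limit, which makes a further limit the most likely outcome for compound 3 as well.

Compound 3 is accordingly expected at 3000 nM in this assay, range 800 nM to 20000 nM, most probably reported again as a limit; the expected step from the E isomer is a step that the limit leaves unreadable from compound 2 to compound 3, which carries no reading beyond the scatter.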

Compound 3, half-maximal inhibitory concentration: > 1000 nM
Compound 3: no number, only a limit (the forecaster's own chance of this, stated with the estimate: 80%); the middle value does not contradict the limit.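

Compound 3 gives > 1000 nM as a limit and not a number. Within the data shown here, compound 2 also stands only at a limit, and no step from compound 2 to compound 3 can be read: the limit of > 1000 nM in this assay, at which 3 of the 3 values shown sit. On these data alone, whether double-bond geometry changes the cytotoxicity in this assay at all stays open: the fact that compounds 2 and 3 differ only in the configuration as drawn.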